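Aryl carbonyl swap: compound 2 to compound 3

The source may report more compounds than this note shows. Statements on the series, on what has been measured and on what is new or still open speak of the compounds shown alone.

Values from an ADME assay on HEK293 cells (Homo sapiens) for cytotoxicity, read by MTT assay, with a stated time of 72 h (on this read-out higher numbers stand for weaker inhibition and lower numbers for stronger inhibition), for the measured compounds:
- compound 1 `COc1ccc(C(=O)N2CCN(CC(=O)N3CCN(CCCc4c[nH]c5ccc(F)cc45)CC3)CC2)cc1` gives 141000 nM
- compound 2 `O=C(CN1CCN(C(=O)c2cccc(F)c2)CC1)N1CCN(CCCc2c[nH]c3ccc(F)cc23)CC1` gives 83000 nM

Compound 2 at 83000 nM lies within the scatter of compound 1, so these two numbers cannot be ranked and only place the series in the same range. Compound 3 `O=C(CN1CCN(C(=O)c2ccccc2Br)CC1)N1CCN(CCCc2c[nH]c3ccc(F)cc23)CC1` is the next compound to be read. It carries 2-bromophenyl in place of 3-fluorophenyl on a carbonyl carbon and is otherwise the same as compound 2.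

For the measured compounds named here, only one measured step bears on this change. It is a 1.7-fold lower number from compound 1 to compound 2 (0.23 log units; within the scatter) with 3-fluorophenyl in place of 4-methoxyphenyl on a carbonyl carbon, and it stays within the scatter. Going by the values given here, no compound with 2-bromophenyl has been measured yet, and a single step is thin evidence. On that basis, no change beyond the scatter is expected in this assay and no direction can be assigned. The expected step is a 1.1-fold higher number from compound 2 to compound 3 (0.06 log units; within the scatter) and this estimate stays within the scatter. The estimate for compound 3 is 95000 nM with 45000 nM to 200000 nM as the expected range.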

Compound 3, half-maximal inhibitory concentration: 77100 nM
Beside the measured number, compound 3's estimate is 1.2-fold (0.09 log units) above it, within the range that was stated.
By their numbers in this assay, from the lowest: compounds 3, 2 and 1 (each within the scatter of the next).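

In this assay the change to 2-bromophenyl on a carbonyl carbon gives a 1.1-fold lower number from compound 2 to compound 3 (0.03 log units; within the scatter) and, set against the 4-methoxyphenyl compound, a 1.8-fold lower number from compound 1 to compound 3 (0.26 log units; within the scatter) so both new steps stay within the scatter and compounds 1, 2 and 3 cannot be ranked. This extends the earlier single comparison: three aryl groups with different substituents, a methoxy group, a fluorine and a bromine, now read in the same range at this place, although these compounds alone set no limit on what the position tolerates. No measurement on record explains why the numbers stay together.

The step from compound 2 to compound 3 changes both the halogen and its printed ring location, so 3-bromophenyl or 2-fluorophenyl would be needed to separate those two changes. Going by these compounds, it also remains open whether any group on this carbonyl carbon can move the number beyond the scatter, for instance an aminophenyl group, a carboxylic acid-bearing phenyl group, or a saturated cyclohexyl group in place of the aryl ring.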